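The source may report more compounds than this note shows. Statements on the series, on what has been measured and on what is new or still open speak of the compounds shown alone.

Three acids sharing one core have numbers in an in vitro functional assay on HEK285-7 cells for antagonist activity at prostaglandin D2 receptor 2 (Homo sapiens), read by BRET and beta-arrestin recruitment; a lower number here means a stronger inhibitor, a higher number a weaker inhibitor. Compound 1, `O=C(O)Cc1sc(COc2ccc(Cl)cc2)nc1-c1ccc(Cl)cc1`, gives 370 nM in this assay. Compound 2, `O=C(O)Cc1sc(C(c2ccccc2)c2ccccc2)nc1-c1ccccc1`, gives 370 nM in this assay. Compound 3, `O=C(O)Cc1sc(C(c2ccc(F)cc2)c2ccc(F)cc2)nc1-c1ccco1`, gives 140 nM in this assay. Compound 3 stands lowest of the three; its nearest neighbour is compound 1, a higher number beyond the scatter, and compound 2 sits as far off, equally beyond the scatter, so compound 3 is the strongest inhibitor of the set as measured. Among the measured compounds shown here, no pair of these three differs in one place only, so no single step between measured compounds can be drawn from them; what compound 1 and compound 2 show is only that two different changes from compound 3 both raise the number.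

Compound 4, `CS(=O)(=O)Nc1cccc(-c2nc(C(c3ccc(F)cc3)c3ccc(F)cc3)sc2CC(=O)O)c1`, is not yet measured in this assay. It differs from compound 3 in one place: 3-(methanesulfonamido)phenyl in place of furan-2-yl on an aromatic carbon. The group that enters is larger than the one that leaves and brings a hydrogen-bond donor where none was. With no measured step of this kind in the set, the expectation rests on compound 3 alone: a small step, at most a modest lowering of the number, is expected, a 1.4-fold lower number from compound 3 to compound 4 (0.15 log units; within the scatter). For compound 4 the estimated value in this assay is 100 nM, expected to lie between 30 nM and 400 nM.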

Compound 4, half-maximal inhibitory concentration: 370 nM
For compound 4 the middle estimate is 3.7-fold (0.57 log units) below the measured one; the range from low to high includes it.
By their numbers in this assay, from the lowest: compound 3; then compounds 1, 2 and 4 (each within the scatter of the next).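

In this assay, 3-(methanesulfonamido)phenyl in place of furan-2-yl, on the aromatic carbon next to the ring nitrogen, gives a 2.6-fold higher number from compound 3 to compound 4 (0.42 log units; beyond the scatter). Among the compounds shown here, this is the first step that can be read at a single place, and it shows that this position is not indifferent to its substituent: with the rest of compound 3 unchanged, the larger group carrying a hydrogen-bond donor gives a weaker inhibitor, though one that still has a measurable number. No measurement here bears on why the number rises.

As far as these compounds go, the step changes the ring and adds the methanesulfonamido group at once, so the share of each remains open, and a plain phenyl at this position on the core of compound 3 would separate the two. Also open, from the compounds shown here alone, is whether an amine, a carboxylic acid or a methoxy group in place of the methanesulfonamido group on that phenyl would give a number closer to that of compound 3 or further from it.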